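A few compounds are considered here, and "the series" means these few. Any claim that something is new, unique, unknown or untested is made for them only; others in the source may bear on it.

Of the compounds shown here, two built on a shared core have been measured in a functional assay on HepG2 cells (Homo sapiens) for antiproliferative activity, read by CCK-8 assay, with a stated time of 72 h; on this read-out higher numbers stand for weaker inhibition and lower numbers for stronger inhibition. Compound 1 `Cc1ccccc1C(=O)Nc1cccc(-c2oc3cc(-c4ccc(F)cc4)ccc3c(=O)c2O)c1` gives 19400 nM in this assay. Compound 2 `O=C(Nc1cccc(-c2oc3cc(-c4ccc(F)cc4)ccc3c(=O)c2O)c1)c1ccc(Br)cc1` gives 13900 nM in this assay. Among the measured compounds shown here, the only step measured so far, a 1.4-fold lower number from compound 1 to compound 2 (0.14 log units; within the scatter), lies within the scatter, so although compound 2 holds the lower of the two numbers, its single neighbour, compound 1, cannot be separated from it on these data.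

Compound 3 `Cc1cc(C(=O)Nc2cccc(-c3oc4cc(-c5ccc(F)cc5)ccc4c(=O)c3O)c2)ccc1F` differs from compound 2 in one place: 4-fluoro-3-methylphenyl in place of 4-bromophenyl on a carbonyl carbon. For the measured compounds named here, the one measured step bears directly on this change, since it likewise exchanges the group on the carbonyl carbon; that step, a 1.4-fold lower number from compound 1 to compound 2 (0.14 log units; within the scatter), stayed within the scatter. On that basis compound 3 is expected to show no step beyond the scatter in this assay, and the expected step is a 1.0-fold higher number from compound 2 to compound 3 (0.02 log units; within the scatter). Compound 3 is accordingly estimated at 14500 nM in this assay, with a range from 6000 nM to 35000 nM to allow for the usual spread of such measurements.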

Compound 3, half-maximal inhibitory concentration: 9540 nM
Compound 3: middle estimate off by 1.5-fold (0.18 log units), on the high side, and the stated range covers the measured number.
By their numbers in this assay, from the lowest: compounds 3, 2 and 1 (each within the scatter of the next, the first and the last beyond it).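

In this assay, 4-fluoro-3-methylphenyl in place of 4-bromophenyl on the carbonyl carbon gives a 1.5-fold lower number from compound 2 to compound 3 (0.16 log units; within the scatter), so these two groups cannot be told apart at this position. Among the compounds shown here, the same group in place of 2-methylphenyl gives a 2.0-fold lower number from compound 1 to compound 3 (0.31 log units; beyond the scatter), the first step at this position to clear the scatter, though only modestly, and it shows that the group on this carbonyl carbon can shift the number in this assay, even though compound 2 remains within the scatter of both neighbours. Nothing available explains why this exchange moves the number.

As far as these compounds go, all three groups at this position are substituted phenyl rings, so it stays open how a saturated ring such as cyclohexyl, a short alkyl chain, or a phenyl ring carrying an amine or a carboxylic acid would read here. From the compounds shown here alone, it also stays open whether the fluorine or the methyl of 4-fluoro-3-methylphenyl accounts for the step, and whether any group on this carbonyl carbon can move the number much further than this modest gain.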